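Replacing methoxyphenyl by chlorophenyl on a shared core

The source may hold more compounds than are shown below. What is called first, only, known or untested is meant among the compounds shown, and "the series" means these compounds.

Measured so far:
compound 1 `O=C1/C(=C\c2ccc(F)cc2)c2ccccc2N1c1c(Cl)cccc1Cl`: 5 ug/mL in a functional assay on MIA PaCa-2 cells (Homo sapiens) for cytotoxicity, read by MTT assay, with a stated time of 72 h; on this read-out lower numbers stand for an effect already at smaller amounts and higher numbers for an effect only at larger amounts of compound
compound 2 `CN(C)c1ccc(/C=C2\C(=O)N(c3c(Cl)cccc3Cl)c3ccccc32)cc1`: > 100 ug/mL
compound 3 `COc1ccc(/C=C2\C(=O)N(c3c(Cl)cccc3Cl)c3ccccc32)cc1`: > 100 ug/mL

The three compounds share one core and differ only in the aryl group hanging from the double-bonded chain carbon. Compound 1, with fluoro on that ring, gives 5 ug/mL. For compound 2 the figure > 100 ug/mL is a limit of the assay, not a number. For compound 3 the figure > 100 ug/mL is likewise a limit. Two of the values thus sit at the limit of > 100 ug/mL in this assay, at which 2 of the 3 values shown sit, so compound 3 stands at the top end of what the numbers can show. The measured steps are an at least 20-fold higher number from compound 1 to compound 2 (1.30 log units; beyond the scatter) and an at least 20-fold higher number from compound 1 to compound 3 (1.30 log units; beyond the scatter); between compound 2 and compound 3 there is a step that the two limits leave unreadable from compound 2 to compound 3.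

Compound 4 `O=C1/C(=C\c2ccccc2Cl)c2ccccc2N1c1c(Cl)cccc1Cl` differs from compound 3 by 2-chlorophenyl in place of 4-methoxyphenyl on a double-bonded chain carbon bound to a double-bonded ring carbon. Going from a halogen to methoxy, compound 1 to compound 3, raised the number strongly; compound 4 returns to a halogen, though now chloro rather than fluoro. The step is therefore expected to run downward and to be large, estimated as an at least 10-fold lower number from compound 3 to compound 4 (1.00 log units; beyond the scatter). In this assay compound 4 is expected to give about 10 ug/mL, within 3 ug/mL to 60 ug/mL.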

Compound 4, concentration for half-maximal effect: > 100 ug/mL
Compound 4 was reported as a limit (the forecaster's own chance of this, stated with the estimate: 25%); middle value at least 10-fold (1.00 log units) from the limit.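

A halogen on this aryl ring is not enough on its own to keep an effect in this assay: with 2-chlorophenyl in place of 4-fluorophenyl on a double-bonded chain carbon bound to a double-bonded ring carbon, the result is an at least 20-fold higher number from compound 1 to compound 4 (1.30 log units; beyond the scatter). Compound 4 gives > 100 ug/mL, which is a limit of the assay and not a number. Compound 1 therefore remains the only one of the four with a readable value, and the steps among compound 2, compound 3 and compound 4 cannot be read, as all three values rest on the same limit: the limit of > 100 ug/mL in this assay, at which 3 of the 4 values shown sit.

The change from 4-fluorophenyl to 2-chlorophenyl alters both the halogen and where it sits on the phenyl ring, and the compounds shown do not separate these two changes. They also leave open how a nitrile or a carboxylic acid on this ring would read, and whether any group other than 4-fluorophenyl at this place can give a value under the limit.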